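From dimethoxyphenyl to trifluorophenyl at the assay limit

The compounds below may be only part of what the source reports. "The series", "measured", "known", "first", "only" and "open" are said of these compounds alone.

Measured in a functional assay on MCF cells (Homo sapiens) for antiproliferative activity, with a stated time of 72 h; a higher number here means a weaker inhibitor, a lower number a stronger inhibitor:
- compound 1 `OC[C@H]1O[C@@H](n2cnc3c(NCc4ccccc4Cl)ncnc32)[C@H](O)[C@@H]1O`: > 166000 nM (a limit)
- compound 2 `OC[C@H]1O[C@@H](n2cnc3c(NCc4cccc(Br)c4)ncnc32)[C@H](O)[C@@H]1O`: > 166000 nM (a limit)
- compound 3 `COc1ccc(CNc2ncnc3c2ncn3[C@@H]2O[C@H](CO)[C@@H](O)[C@H]2O)c(OC)c1`: > 166000 nM (a limit)

Compound 3 stands at > 166000 nM, which is a limit and not a number. It shares that reading with the other two compounds: the limit of > 166000 nM in this assay, at which 3 of the 3 values shown sit.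

The next compound is compound 4 `OC[C@H]1O[C@@H](n2cnc3c(NCc4c(F)ccc(F)c4F)ncnc32)[C@H](O)[C@@H]1O`. The change is 2,3,6-trifluorophenyl in place of 2,4-dimethoxyphenyl on a saturated chain carbon bound to a nitrogen on an aromatic ring.

Three measured steps swap the group at this same place: a step that the two limits leave unreadable from compound 1 to compound 2, a step that the two limits leave unreadable from compound 1 to compound 3 and a step that the two limits leave unreadable from compound 2 to compound 3. None has a readable size, so they give no direction. All three compounds nevertheless remained at the limit in this assay, so no step beyond the scatter is expected, and the estimated change is a number no higher from compound 3 to compound 4 (the limit leaves the size open). Compound 4 is estimated at 166000 nM, with an expected range from 80000 nM to 300000 nM, and will most likely be reported only as a limit.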

Compound 4, half-maximal inhibitory concentration: > 166000 nM
Compound 4: no number, only a limit (the forecaster's own chance of this, stated with the estimate: 85%); the middle value lies on the limit itself.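

Compound 4 also gives only a limit, so its steps from compound 1, compound 2 and compound 3 cannot be read. How strongly any of these compounds acts in this assay and whether changing this group alters activity at all stay open.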